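A Hydroxy Group Added to a Triazole Series

The compounds below may be only part of what the source reports. "The series", "measured", "known", "first", "only" and "open" are said of these compounds alone.

Measured compounds:
compound 1 `COc1ccc(-c2cn(-c3ccc(OC(F)(F)F)cc3)nn2)cc1O` — > 10000 nM in a functional assay on MDA-MB-231 cells (Homo sapiens) for cytotoxicity, read by MTT assay; a lower number here means a stronger inhibitor, a higher number a weaker inhibitor
compound 2 `COc1ccc(-n2cc(-c3ccc(O)c(OC)c3)nn2)cc1` — > 10000 nM
compound 3 `COc1ccc(-c2cn(-c3ccc(OC(F)(F)F)cc3)nn2)cc1` — 1000 nM

Compound 3 is the only one of the three with a numerical value: in this assay compound 3 gives 1000 nM. Compound 1 carries a hydroxy in place of hydrogen on an aromatic carbon, (hydroxy in place of hydrogen on an aromatic carbon). For compound 1 this assay reports only a limit, > 10000 nM. The step is an at least 10-fold higher number from compound 3 to compound 1 (1.00 log units; beyond the scatter), so the added hydroxy weakens the compound in this assay; how far it goes is not known because the limit of > 10000 nM in this assay, at which 2 of the 3 values shown sit, caps what can be seen.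

Compound 2 has a different core from compound 3, and the difference between the two cores is not broken down here. For compound 2 this assay again reports only a limit, > 10000 nM.

Compound 4 `COc1ccc(-n2cc(-c3ccc(O)c(OC)c3)nn2)cc1O` is yet to be measured. It stands to compound 2 as compound 1 stands to compound 3: hydroxy in place of hydrogen on an aromatic carbon, the same kind of change at the same kind of place. Among the measured compounds shown here, since compound 2 already sits at the limit, and the one measured instance of this change weakened compound 3 to compound 1 beyond the scatter, the step from compound 2 to compound 4 is expected to be a step that the limit leaves unreadable from compound 2 to compound 4, most likely leaving compound 4 at or beyond the limit. Compound 4 is therefore estimated at 20000 nM, with a range from 8000 nM to 60000 nM.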

Compound 4, half-maximal inhibitory concentration: > 10000 nM
Compound 4: a limit, no number; the forecaster's own chance of this, stated with the estimate: 85%; the middle value does not contradict the limit.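

Compound 4 gives > 10000 nM, which is a limit and not a number. With compound 2 also reported only as a limit, no step can be read from compound 2 to compound 4: the limit of > 10000 nM in this assay, at which 3 of the 4 values shown sit.

The compounds shown leave open whether the added hydroxy changes the activity of compound 2 at all, and how large the weakening from compound 3 to compound 1 really is.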